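The source may hold more compounds than are shown below. What is called first, only, known or untested is meant among the compounds shown, and "the series" means these compounds.

Three measured compounds share a design in which an anilino group bearing a single para substituent sits on a pyrimidine that carries a bicyclic core. Compound 1 has the structure `Cc1ccc(Nc2nccc(-c3ccnc4ccccc34)n2)cc1` and compound 2 has the structure `FC(F)(F)c1ccc(Nc2nccc(-c3ccnc4ccccc34)n2)cc1`. In a functional assay on PC-3 cells (Homo sapiens) for cytotoxicity, read by sulforhodamine B assay, with a stated time of 48 h, tested at 50 uM (a lower number here means less inhibition, a higher number more inhibition at the concentration tested (going by the name of the read-out)), compound 1 gives 100%, and compound 2 gives 87.3%. The only structural difference between these two is trifluoromethyl in place of methyl on an aromatic carbon, and the measured step is a number 12.7 percentage points lower from compound 1 to compound 2 (beyond the scatter).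

Compound 3 has the structure `Cc1ccc(Nc2nccc(-c3c(C)nc4ccccn34)n2)cc1` and carries a different core from compound 1; the difference between the two cores is not broken down here. In this assay compound 3 gives 94.2%, a value within the usual scatter of that of compound 1.

Compound 4 has the structure `Cc1nc2ccccn2c1-c1ccnc(Nc2ccc(C(F)(F)F)cc2)n1` and has not yet been measured. It differs from compound 3 by trifluoromethyl in place of methyl on an aromatic carbon, the same change that turns compound 1 into compound 2. If that step carries over onto the core of compound 3, the expected step from compound 3 to compound 4 is a number 12.2 percentage points lower from compound 3 to compound 4 (beyond the scatter), resting on the measured step of a number 12.7 percentage points lower from compound 1 to compound 2 (beyond the scatter). On that basis the estimate for compound 4 is 82%.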

Compound 4, a percentage reported as inhibition, at one concentration (the size of the read-out at that concentration, not a potency): 64.5%
Estimate against measurement, compound 4: 17.5 percentage points above, and the stated range ends above it.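

In this assay trifluoromethyl in place of methyl brings a number 29.7 percentage points lower from compound 3 to compound 4 (beyond the scatter) on the core of compound 3, and setting this beside the earlier step shows that the number falls on both cores but not by the same amount: the same change on two cores in this assay, a number 12.7 percentage points lower (beyond the scatter) from compound 1 to compound 2 and a number 29.7 percentage points lower (beyond the scatter) from compound 3 to compound 4, 17 percentage points apart, beyond the scatter of two such steps.

Within this pair of cores, then, the direction of the change carried over while its size did not, so a step measured on one core gave the sign but not the size of the step on the other. For the compounds shown here, this does not show why the two steps differ, and with only two cores, tested at a single concentration, it cannot show how the change would behave on a third core.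

The compounds shown leave open how other groups in the same place, such as an amine, a carboxylic acid or a longer chain, would fare on either core. They also leave open whether those groups would show the same dependence on the core.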